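From a 4-cyanophenyl group to pyrimidin-2-yl

The source may hold more compounds than are shown below. What is called first, only, known or untested is meant among the compounds shown, and "the series" means these compounds.

In a functional assay on COR-L23 cells (Homo sapiens) for antiproliferative activity, read by CellTiter-Glo, with a stated time of 4 days (on this read-out higher numbers stand for weaker inhibition and lower numbers for stronger inhibition), three compounds built on a shared core have been measured. Compound 1 `C[C@H](NC(=O)[C@@H]1CCCN1C)c1ccc(NC(=O)[C@H]2C[C@@H]2c2cccnc2)cc1` gives 11 nM, compound 2 `C[C@H](NC(=O)c1ccccc1)c1ccc(NC(=O)[C@H]2C[C@@H]2c2cccnc2)cc1` gives 8 nM, and compound 3 `C[C@H](NC(=O)c1ccc(C#N)cc1)c1ccc(NC(=O)[C@H]2C[C@@H]2c2cccnc2)cc1` gives 19 nM. Two steps fix where compound 3 stands: there is a 1.7-fold higher number from compound 1 to compound 3 (0.24 log units; within the scatter), and there is a 2.4-fold higher number from compound 2 to compound 3 (0.38 log units; beyond the scatter). It is therefore level with one neighbour and modestly separated from the other.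

Compound 4 `C[C@H](NC(=O)c1ncccn1)c1ccc(NC(=O)[C@H]2C[C@@H]2c2cccnc2)cc1` keeps the shared core and carries pyrimidin-2-yl in place of 4-cyanophenyl on a carbonyl carbon, (pyrimidin-2-yl in place of 4-cyanophenyl on a carbonyl carbon). For the measured compounds named here, no measured step makes this exact exchange, and no measured compound carries pyrimidin-2-yl, so the evidence is indirect. The closest guide is the set of changes at the same carbonyl carbon. One of these is a 1.4-fold lower number from compound 1 to compound 2 (0.14 log units; within the scatter), and the two steps to compound 3 given above are the others. Even the largest of the three is modest, so a large move in this assay is not expected here. Compound 4 also lacks the cyano group, as does compound 2 at 8 nM, which gives a slight lean towards a lower number. Little or no change beyond the scatter is therefore expected. The estimated step is a 1.3-fold lower number from compound 3 to compound 4 (0.10 log units; within the scatter). For compound 4 the expected value is 15 nM, with an estimated range of 5 nM to 45 nM.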

Compound 4, half-maximal inhibitory concentration: 17 nM
The estimate for compound 4 lay 1.1-fold (0.05 log units) below the measured number, and the stated range covers the measured number.
By their numbers in this assay, from the lowest: compounds 2, 1, 4 and 3 (each within the scatter of the next, the first and the last beyond it).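

Pyrimidin-2-yl, a six-membered aromatic ring with 2 hetero atoms and no triple bond, reads level with 4-cyanophenyl on this carbonyl carbon in this assay (a 1.1-fold lower number from compound 3 to compound 4 (0.05 log units; within the scatter)), so the nitrile is not needed for a value in this range. The earlier compounds shown here showed a modest separation from phenyl only for 4-cyanophenyl (a 2.4-fold higher number from compound 2 to compound 3 (0.38 log units; beyond the scatter)), and pyrimidin-2-yl now shows one as well (a 2.1-fold higher number from compound 2 to compound 4 (0.33 log units; beyond the scatter)), so phenyl stands modestly apart from two different aromatic groups. The saturated 1-methylpyrrolidin-2-yl group remains level with pyrimidin-2-yl (a 1.5-fold higher number from compound 1 to compound 4 (0.19 log units; within the scatter)), as it is with phenyl and with 4-cyanophenyl, so every exchange at this position so far is modest at most, and the position has shown no large step in either direction.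

The compounds shown give no measured basis for saying why pyrimidin-2-yl and 4-cyanophenyl read alike or why both sit modestly apart from phenyl. Still open, from the compounds shown here alone, is what pyridin-2-yl, a 4-aminophenyl group or a 4-carboxyphenyl group would give on this carbonyl carbon, and whether any of them would break out of this narrow band.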